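A few compounds are considered here, and "the series" means these few. Any claim that something is new, unique, unknown or untested is made for them only; others in the source may bear on it.

Compound 1 `O=C(Nc1ccc(F)c(-c2nc3ncc(-c4cccc(F)c4)cc3[nH]2)c1)N1CCCC1`: 15000 ng.h/mL. Compound 2 `O=C(Nc1ccc(F)c(-c2nc3ncc(-c4cncc(F)c4)cc3[nH]2)c1)N1CCCC1`: 1560 ng.h/mL.

Compound 1 stands highest of the two numbers in an ADME assay on the whole organism (Mus musculus, strain Swiss Webster) for pharmacokinetics, read by LC-MS, at a dose of 50 mg/kg by the oral route; on this read-out lower numbers stand for lower exposure and higher numbers for higher exposure at the dose given; compound 2 comes in lower, a 9.6-fold lower number from compound 1 to compound 2 (0.98 log units; beyond the scatter). Compound 3 `O=C(Nc1ccc(F)c(-c2nc3ncc(-c4ccc(O)cc4)cc3[nH]2)c1)N1CCCC1` has not yet been measured. It differs from compound 1 in one place: 4-hydroxyphenyl in place of 3-fluorophenyl on an aromatic carbon. Among the measured compounds shown here, the only measured step alters the same aromatic carbon, with a different group, and it lowered the number beyond the scatter; a lower number is therefore expected for compound 3 as well, by an estimated 5.0-fold lower number from compound 1 to compound 3 (0.70 log units; beyond the scatter). The exposure of compound 3 is estimated at 3000 ng.h/mL, within a range of 800 ng.h/mL to 10000 ng.h/mL.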

Compound 3, area under the concentration-time curve: 137 ng.h/mL
Estimate against measurement, compound 3: 22-fold (1.34 log units) above; measured number below the stated range.
By their numbers in this assay, from the lowest: compound 3; then compound 2; then compound 1.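

The exposure at this aromatic carbon depends strongly on which ring sits there: 4-hydroxyphenyl in place of 3-fluorophenyl gives a 110-fold lower number from compound 1 to compound 3 (2.04 log units; beyond the scatter) in this assay and exceeds the fall seen with 5-fluoropyridin-3-yl. The same group also gives an 11-fold lower number from compound 2 to compound 3 (1.06 log units; beyond the scatter) so the two replacement rings are clearly not equivalent. Nothing available here explains this fall.

From the compounds shown here alone, it remains open whether the hydroxyl group itself or its place on the ring matters more. A 4-methoxyphenyl or 3-hydroxyphenyl group would separate those two possibilities.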